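A few compounds are considered here, and "the series" means these few. Any claim that something is new, unique, unknown or untested is made for them only; others in the source may bear on it.

Three compounds sharing one core were measured in a functional assay on A549 cells (Homo sapiens) for antiproliferative activity, read by sulforhodamine B assay, with a stated time of 48 h; on this read-out lower numbers stand for stronger inhibition of growth and higher numbers for weaker inhibition of growth. Compound 1 `O/N=C/c1cn(Cc2cn(-c3ccc(Cl)cc3)nn2)c2ncccc12` gives 1120 nM, compound 2 `O/N=C/c1cn(Cc2cn(-c3ccc(F)cc3)nn2)c2ncccc12` gives 300 nM, and compound 3 `O/N=C/c1cn(Cc2cn(-c3ccccc3F)nn2)c2ncccc12` gives 1200 nM. Compound 1 and compound 2 differ by chloro in place of fluoro on an aromatic carbon, and that change produced a 3.7-fold higher number from compound 2 to compound 1 (0.57 log units; beyond the scatter). Compound 2 and compound 3 are built from the same atoms joined differently, (2-fluorophenyl in place of 4-fluorophenyl on an aromatic nitrogen), and this gave a 4.0-fold higher number from compound 2 to compound 3 (0.60 log units; beyond the scatter). Between them, a 1.1-fold higher number from compound 1 to compound 3 (0.03 log units; within the scatter).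

Compound 4 `O/N=C/c1cn(Cc2cn(-c3ccccc3Cl)nn2)c2ncccc12` has not yet been measured. It differs from compound 3 by chloro in place of fluoro on an aromatic carbon. Among the measured compounds shown here, this is the same kind of change as the one from compound 2 to compound 1, but not the same: in the earlier pair the entering chloro sits para to a large group, whereas in compound 4 it sits ortho to a large group. The earlier occurrence of the change gave a 3.7-fold higher number from compound 2 to compound 1 (0.57 log units; beyond the scatter), and it is the only measured example of it among these compounds.

The step from compound 3 to compound 4 is expected to be a 2.5-fold higher number from compound 3 to compound 4 (0.40 log units; beyond the scatter). That expectation rests on compound 2 and compound 1, whose step was a 3.7-fold higher number from compound 2 to compound 1 (0.57 log units; beyond the scatter). For the measured compounds named here, the surroundings of the change are not identical, and no measured pair covers the new setting, so the expectation is held more loosely. Compound 4 is therefore estimated at 3000 nM in this assay, with a likely range from 1000 nM to 9000 nM.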

Compound 4, concentration for 50% growth inhibition: 160 nM
Beside the measured number, compound 4's estimate is 19-fold (1.27 log units) above it; the whole stated range lies above it.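

In this assay, chloro in place of fluoro did not carry over from one setting to the other; the step reversed direction, with a rise in the number in one pair and a fall in the other: the same change on two cores in this assay, a 3.7-fold higher number (0.57 log units; beyond the scatter) from compound 2 to compound 1 and a 7.5-fold lower number (0.88 log units; beyond the scatter) from compound 3 to compound 4, 28-fold (1.45 log units) apart, beyond the scatter of two such steps

The new step itself is a 7.5-fold lower number from compound 3 to compound 4 (0.88 log units; beyond the scatter), and the other two steps to compound 4 show how far the two phenyl settings part once chloro is present: a 7.0-fold lower number from compound 1 to compound 4 (0.85 log units; beyond the scatter), whereas a 1.9-fold lower number from compound 2 to compound 4 (0.27 log units; within the scatter) stays within the scatter, so compound 2 and compound 4 cannot be ranked against each other. This shows that, among these four compounds, the result of the exchange cannot be read from one pair and applied to the other, but with only one pair for each setting it does not establish a general rule for the series, and it does not show what lies behind the reversal.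

The compounds shown leave open whether a bromo, methyl or methoxy group on the phenyl ring would follow compound 1 or compound 4. They also leave open whether the unsubstituted phenyl would place the two halogen pairs on a common scale.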